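Furan-2-yl ketone on the bicyclic amine core

The source may hold more compounds than are shown below. What is called first, only, known or untested is meant among the compounds shown, and "the series" means these compounds.

Compound 3 `O=C(C1CC1)[C@H]1C[C@H]2CNC[C@H]2C1` gives the lowest number among the three measured compounds in an assay on CHO cells for displacement of a labelled ligand from Neuronal acetylcholine receptor; alpha3/beta4 (Homo sapiens), read by scintillation counting, with a stated time of 2 h (on this read-out lower numbers stand for stronger inhibition and higher numbers for weaker inhibition), at 70 nM. Compound 1 `C[C@@H]1C[C@@H]1C(=O)N1CC2CNCC2C1` gives 280 nM in this assay, and compound 2 `CCC(=O)N1CC2CNCC2C1` gives 2100 nM. Going by the values given here, the one measured step that changes the group on the carbonyl carbon, a 7.5-fold higher number from compound 1 to compound 2 (0.88 log units; beyond the scatter), shows that this position matters for this assay. Compound 4 `O=C(c1ccco1)[C@H]1C[C@H]2CNC[C@H]2C1` differs from compound 3 by furan-2-yl in place of cyclopropyl on a carbonyl carbon. Among the compounds with values here, no measured step swaps a cyclopropyl for an aromatic ring, so the direction is uncertain; a modest loss is expected, with a 2.1-fold higher number from compound 3 to compound 4 (0.33 log units; beyond the scatter). Compound 4 is therefore expected to give about 150 nM in this assay, plausibly between 40 nM and 600 nM.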

Compound 4, inhibition constant: 2200 nM
The estimate for compound 4 lay 15-fold (1.17 log units) below the measured number; the whole stated range lies below it.
By their numbers in this assay, from the lowest: compound 3; then compound 1; then compounds 2 and 4 (each within the scatter of the next).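

Cyclopropyl and furan-2-yl are both rings on this carbonyl carbon, yet in this assay the swap gives a 31-fold higher number from compound 3 to compound 4 (1.50 log units; beyond the scatter) in a single change. Going by these compounds alone, the earlier step showed only that the group on a carbonyl carbon matters; this one shows that keeping a ring there does not preserve the number, and that the larger aromatic ring with its oxygen is poorly tolerated on this core. From the compounds shown here alone, whether cyclobutyl, cyclopentyl or a phenyl ring would keep the number near that of compound 3 stays open. Nothing measured here explains the size of this step.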